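A few compounds are considered here, and "the series" means these few. Any claim that something is new, unique, unknown or untested is made for them only; others in the source may bear on it.

In a functional assay on K562 cells (Homo sapiens) for antiproliferative activity, with a stated time of 72 h (a lower number here means a stronger inhibitor, a higher number a weaker inhibitor), three compounds share one core and differ only in the group on a saturated chain carbon bound to a nitrogen on an aromatic ring. Compound 1 `Cc1ccc(CNc2ncnc3c2ncn3[C@@H]2O[C@H](CO)[C@@H](O)[C@H]2O)cc1` returns only a limit, > 166000 nM. Compound 2 `OC[C@H]1O[C@@H](n2cnc3c(NCc4ccc(Cl)cc4Cl)ncnc32)[C@H](O)[C@@H]1O` gives 106000 nM. Compound 3 `OC[C@H]1O[C@@H](n2cnc3c(NCc4ccc(Cl)c(Cl)c4)ncnc32)[C@H](O)[C@@H]1O` gives 10800 nM, the lowest number of the three, which makes it the strongest inhibitor so far.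

Compound 4 `COc1cccc(CNc2ncnc3c2ncn3[C@@H]2O[C@H](CO)[C@@H](O)[C@H]2O)c1OC` carries 2,3-dimethoxyphenyl in place of the 3,4-dichlorophenyl of compound 3: 2,3-dimethoxyphenyl in place of 3,4-dichlorophenyl on a saturated chain carbon bound to a nitrogen on an aromatic ring. Two measured steps change this same group. The step of a 9.8-fold lower number from compound 2 to compound 3 (0.99 log units; beyond the scatter) is modest, and the step of an at least 15-fold lower number from compound 1 to compound 3 (1.18 log units; beyond the scatter) is large. Both show that the number moves when this group changes, and only the 3,4-dichlorophenyl group has reached the low value of compound 3. With that group gone, a weaker result in this assay is expected, and the estimated change is a 6.5-fold higher number from compound 3 to compound 4 (0.81 log units; beyond the scatter). For compound 4 the expected value is 70000 nM, within an estimated range of 18000 nM to 170000 nM.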

Compound 4, half-maximal inhibitory concentration: > 166000 nM
Compound 4 ended at the assay's limit; the forecaster's own chance of this, stated with the estimate: 35%; at least 2.3-fold (0.37 log units) between middle value and limit.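

Compound 4 returns only a limit in this assay, the same limit that compound 1 returned: the limit of > 166000 nM in this assay, at which 2 of the 4 values shown sit. The new result adds a group with oxygen atoms and hydrogen-bond acceptors to the series, and 2,3-dimethoxyphenyl does not keep the low value of the 3,4-dichlorophenyl group, with an at least 15-fold higher number from compound 3 to compound 4 (1.18 log units; beyond the scatter). Against the 2,4-dichlorophenyl group the result is an at least 1.5-fold higher number from compound 2 to compound 4 (0.19 log units; that floor lies within the scatter), which fixes no order between the two, and the step between the two compounds at the limit cannot be read.

Going by these compounds, how weak the two compounds at the limit really are remains unknown. On these data alone, it also remains open how a phenyl ring carrying an amine or a carboxylic acid would fare at this position, or a longer chain in place of the saturated chain carbon.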